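Swapping a phenyl for thiophen-2-yl in compound 3

The compounds below may be only part of what the source reports. "The series", "measured", "known", "first", "only" and "open" are said of these compounds alone.

Measured in a functional assay on HCT-116 cells (Homo sapiens) for inhibition, read by MTT assay, with a stated time of 48 h; a higher number here means a weaker inhibitor, a lower number a stronger inhibitor:
- compound 1 `COc1cc(-c2cc(-c3ccc(Br)cc3)nc(-c3ccccc3)n2)cc(OC)c1OC`: 4320 nM
- compound 2 `COc1cc(-c2cc(-c3cccc(O)c3)nc(-c3ccccc3)n2)cc(OC)c1OC`: 20400 nM
- compound 3 `COc1cc(-c2cc(-c3ccccc3)nc(-c3ccccc3)n2)cc(OC)c1OC`: 9950 nM

Among these three numbers, compound 3 stands in the middle, second highest, at 9950 nM. The next analogue, compound 4 `COc1cc(-c2cc(-c3cccs3)nc(-c3ccccc3)n2)cc(OC)c1OC`, keeps the shared core but carries thiophen-2-yl in place of phenyl on an aromatic carbon. Going by the values given here, no measured step makes this ring swap, so the evidence is only indirect. The closest guide comes from changes on the phenyl that now leaves. Replacing bromo with hydrogen gave a 2.3-fold higher number from compound 1 to compound 3 (0.36 log units; beyond the scatter), and replacing hydroxy with hydrogen gave a 2.1-fold lower number from compound 2 to compound 3 (0.31 log units; beyond the scatter). Both steps were modest, and they ran in opposite directions, so neither points a way for the swap. In this assay, from the compounds shown here alone, no step beyond the scatter is therefore expected, and the direction stays open. The expected step is a 1.1-fold lower number from compound 3 to compound 4 (0.04 log units; within the scatter). For compound 4 the estimated value is 9000 nM, with an expected range of 3500 nM to 23000 nM.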

Compound 4, half-maximal inhibitory concentration: 17000 nM
Compound 4: middle estimate off by 1.9-fold (0.28 log units), on the low side; the range from low to high includes it.
By their numbers in this assay, from the lowest: compound 1; then compounds 3, 4 and 2 (each within the scatter of the next, the first and the last beyond it).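

In this assay, going by these compounds alone, the ring swap itself, read directly for the first time here, stays within the scatter (a 1.7-fold higher number from compound 3 to compound 4 (0.23 log units; within the scatter)), so at this position the five-membered thiophen-2-yl ring with its sulfur reads much like phenyl. The same holds against the 3-hydroxyphenyl group (a 1.2-fold lower number from compound 2 to compound 4 (0.08 log units; within the scatter)), while the 4-bromophenyl group remains apart (a 3.9-fold higher number from compound 1 to compound 4 (0.59 log units; beyond the scatter)), which leaves compound 1 as the only one of these four beyond the scatter of thiophen-2-yl. No measurement shown here accounts for these numbers.

Still open, from the compounds shown here alone, is how a furan-2-yl ring, or an amine or a carboxylic acid on this ring, would read in this assay. Also open, going by these compounds, is whether a bromo on the thiophen-2-yl ring would give a step like the one it gives on phenyl.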